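This account rests on a few compounds, and the source may have more. Where it says the series, first, only, none or still open, it means among the compounds named here.

In a functional assay on MDA-MB-231 cells (Homo sapiens) for antiproliferative activity, read by MTT assay, with a stated time of 72 h (on this read-out higher numbers stand for weaker inhibition and lower numbers for stronger inhibition), compound 1 (`O=C(CCc1cccc2c1B(O)OC2)Nc1cccc(Br)c1`) gives 720 nM, compound 2 (`O=C(CCc1cccc2c1B(O)OC2)Nc1cccc(I)c1`) gives 5300 nM and compound 3 (`O=C(CCc1cccc2c1B(O)OC2)Nc1cccc(-c2ccc(F)cc2)c1`) gives 250 nM. Compound 3 thus holds the lowest number of the three, and its gaps to both others lie beyond the scatter. Compound 4 (`O=C(CCc1cccc2c1B(O)OC2)Nc1cccc(-c2ccc(OC(F)(F)F)cc2)c1`) has trifluoromethoxy in place of fluoro on an aromatic carbon, para to a large group (trifluoromethoxy in place of fluoro on an aromatic carbon). Going by the values given here, no measured step alters this fluoro group. The available steps exchange only bromo, iodo and 4-fluorophenyl, so they bear on the change only indirectly. Two are modest, a 7.4-fold higher number from compound 1 to compound 2 (0.87 log units; beyond the scatter) and a 2.9-fold lower number from compound 1 to compound 3 (0.46 log units; beyond the scatter), while a 21-fold lower number from compound 2 to compound 3 (1.33 log units; beyond the scatter) is large. They show that a single exchange can shift this read-out considerably, but they give no firm direction for the new one. The expected outcome in this assay is no step beyond the scatter, with room for a modest one either way, and the estimated step is a 1.4-fold higher number from compound 3 to compound 4 (0.15 log units; within the scatter). For compound 4 the estimated value is 350 nM, with an expected range of 100 nM to 1200 nM.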

Compound 4, half-maximal inhibitory concentration: 640 nM
The estimate for compound 4 lay 1.8-fold (0.26 log units) below the measured number; the range from low to high includes it.
By their numbers in this assay, from the lowest: compound 3; then compounds 4 and 1 (each within the scatter of the next); then compound 2.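

Going by these compounds alone, the earlier steps exchanged only bromo, iodo and 4-fluorophenyl, whereas this is the first step that alters the group on the six-membered aromatic ring of carbon only, para to a large group. In this assay, trifluoromethoxy in place of fluoro, with 5 heavy atoms entering and 1 heavy atom leaving, gives a 2.6-fold higher number from compound 3 to compound 4 (0.41 log units; beyond the scatter), so the read-out responds to the group at this place, though far less than in the largest earlier step, a 21-fold lower number from compound 2 to compound 3 (1.33 log units; beyond the scatter). Nothing shown explains why this exchange raises the number.

With only fluoro and trifluoromethoxy at this place, the compounds shown cannot establish a trend there. On these data alone, it stays open whether methoxy, an amine or a carboxylic acid at this place would give a number nearer that of compound 3 or that of compound 4.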